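The source may hold more compounds than are shown below. What is called first, only, known or untested is meant among the compounds shown, and "the series" means these compounds.

In a functional assay on B16 cells (Mus musculus) for inhibition (a higher number here means a weaker inhibitor, a lower number a stronger inhibitor), compound 1 `CC(C)CN(NC(=O)OCc1ccccc1)C(=O)CN(Cc1ccccc1)NC(=O)Cc1cccc(Br)c1` gives > 80000 nM, which is a limit of the assay and not a number. Compound 2 `CC(C)CN(CC(=O)N(CC(C)C)NC(=O)OCc1ccccc1)/N=C/c1ccccc1B(O)O` gives 26300 nM, and compound 3 `CC(C)CN(CC(=O)N(Cc1ccccc1)NC(=O)OCc1ccccc1)/N=C/c1ccccc1B(O)O` gives 33500 nM. The measured step between these two is a 1.3-fold higher number from compound 2 to compound 3 (0.11 log units; within the scatter), so compound 3 stands level with compound 2 on these numbers.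

Compound 4 `CC(C)CN(CC(=O)N(Cc1ccccc1)NC(=O)OCc1ccccc1)/N=C/c1cccc(B(O)O)c1` changes one part of compound 3: a group of 9 heavy atoms (6 carbon, 1 boron, 2 oxygen; one six-membered aromatic ring of carbon only) in place of a group of 9 heavy atoms (6 carbon, 1 boron, 2 oxygen; one six-membered aromatic ring of carbon only), on a carbon with a double bond to nitrogen. The two groups have the same atoms, joined differently, and the change sits on a carbon with a double bond to nitrogen.

Among the measured compounds shown here, only one measured step is available as a guide, and it concerns a different part of the molecule, where phenyl stands in place of isopropyl on a saturated chain carbon. For the measured compounds named here, no measured pair tests a rearrangement of this group, so the data give no direction for the change. The small size of a 1.3-fold higher number from compound 2 to compound 3 (0.11 log units; within the scatter) offers only indirect support for expecting little movement, and the expectation is therefore for no shift beyond the scatter, held with wide uncertainty. The expected step is a 1.1-fold lower number from compound 3 to compound 4 (0.05 log units; within the scatter). For compound 4 the estimated value is 30000 nM, with an expected range from 13000 nM to 70000 nM.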

Compound 4, half-maximal inhibitory concentration: 20500 nM
Compound 4: middle estimate off by 1.5-fold (0.17 log units), on the high side, within the range that was stated.
By their numbers in this assay, from the lowest: compounds 4, 2 and 3 (each within the scatter of the next). At a limit, above all of these: compound 1.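

In this assay, among the compounds shown here, the first change at this place, on a carbon with a double bond to nitrogen, gives a 1.6-fold lower number from compound 3 to compound 4 (0.21 log units; within the scatter). The two groups have the same atoms, joined differently, and this rearrangement does not separate compound 3 from compound 4 on these numbers. That adds a second place to the earlier one, whose change gave a 1.3-fold higher number from compound 2 to compound 3 (0.11 log units; within the scatter), so each single change shown so far stays within the scatter, and nothing shown gives a reason for either result.

From the compounds shown here alone, it remains open whether a carboxylic acid on the same ring, in place of the boron and its two oxygens, would give a number like those of compound 3 and compound 4, and the same question stands for a ring carrying only hydrogen there. It is also open whether a longer chain between the carbon with a double bond to nitrogen and the ring would produce a step beyond the scatter, which neither of the two steps shown here does.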